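Swapping a Thiocarbamate for an Ethyl Carbamate

This account rests on a few compounds, and the source may have more. Where it says the series, first, only, none or still open, it means among the compounds named here.

Measured compounds in an assay on cell membranes for displacement of a labelled ligand from proteinase-activated receptor 1 (Homo sapiens), read by scintillation counting, with a stated time of 60 min; a lower number here means a stronger inhibitor, a higher number a weaker inhibitor:
- compound 1 `CC(=O)OC1C[C@@H]2CCCC[C@@H]2[C@H]1/C=C/c1ccc(-c2cccc(F)c2)cn1`: 67 nM
- compound 2 `O=C(Nc1ccccc1)OC1C[C@@H]2CCCC[C@@H]2[C@H]1/C=C/c1ccc(-c2cccc(F)c2)cn1`: 360 nM
- compound 3 `CN(C)C(=S)OC1C[C@@H]2CCCC[C@@H]2[C@H]1/C=C/c1ccc(-c2cccc(F)c2)cn1`: 120 nM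

All three share one core and differ only in the group carried on an oxygen on a saturated carbon of the five-membered ring. Compound 3 stands second highest of the three numbers: compound 1 lies close, a 1.8-fold higher number from compound 1 to compound 3 (0.25 log units; within the scatter), while compound 2 lies further off, a 3.0-fold lower number from compound 2 to compound 3 (0.48 log units; beyond the scatter). Going by the values given here, the one clearly weaker compound, compound 2, carries the anilino carbamate, a 5.4-fold higher number from compound 1 to compound 2 (0.73 log units; beyond the scatter).

Compound 4 `CCOC(=O)NC1C[C@@H]2CCCC[C@@H]2[C@H]1/C=C/c1ccc(-c2cccc(F)c2)cn1` is the next step. The change is a group of 6 heavy atoms (3 carbon, 1 nitrogen, 2 oxygen; no ring) in place of a group of 6 heavy atoms (3 carbon, 1 nitrogen, 1 oxygen, 1 sulfur; no ring), on a saturated ring carbon, on a saturated ring carbon of a five-membered non-aromatic ring of carbon only, part of a fused or bridged system of two rings. Here the link to the ring switches from oxygen to nitrogen, and nothing measured so far bears directly on that switch. What the measured steps show is that a small group in this position, whether acetyl or dimethylthiocarbamoyl, gives a similar number, and that only the larger phenyl carbamate of compound 2 costs a modest step. The entering (ethoxycarbonyl)amino is small, so the expected step is a 1.5-fold lower number from compound 3 to compound 4 (0.18 log units; within the scatter), within or near the scatter. Compound 4 is thus estimated at 80 nM, with a range from 25 nM to 250 nM.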

Compound 4, half-maximal inhibitory concentration: 2000 nM
For compound 4 the middle estimate is 25-fold (1.40 log units) below the measured one; the measured number lies above the stated range.
By their numbers in this assay, from the lowest: compounds 1 and 3 (each within the scatter of the next); then compound 2; then compound 4.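

In this assay, size alone does not account for this position: the (ethoxycarbonyl)amino group has the same count of 6 heavy atoms as the group it replaces, yet the swap brings a large loss (a 17-fold higher number from compound 3 to compound 4 (1.22 log units; beyond the scatter)). Even the bulkier (phenylcarbamoyl)oxy group does better than the entering group (a 5.6-fold higher number from compound 2 to compound 4 (0.74 log units; beyond the scatter)), and so does the small acetoxy group (a 30-fold higher number from compound 1 to compound 4 (1.47 log units; beyond the scatter)). Going by these compounds alone, the one compound joined to the ring through nitrogen is therefore the weakest of the four, and the earlier picture, in which a small group here gave a similar number, does not extend to it.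

The change replaces the link to the ring and the rest of the group in one step, so the compounds shown cannot say which part carries the loss; a plain amine or an acetamide on this ring carbon, or an ethyl carbonate joined through oxygen, would separate the two. Nothing available here gives a measured reason for the drop.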